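The compounds below may be only part of what the source reports. "The series", "measured", "known", "first", "only" and "open" are said of these compounds alone.

Measured so far in a functional assay on UACC-257 cells (Homo sapiens) for inhibition, read by sulforhodamine B assay, with a stated time of 48 h; on this read-out lower numbers stand for stronger inhibition of growth and higher numbers for weaker inhibition of growth:
compound 1 `COc1ccc(-c2cc(/C=C/C(=O)c3ccc(N)cc3)[nH]n2)cc1`, 4210 nM
compound 2 `COc1cc(-c2cc(/C=C/C(=O)c3ccc(N)cc3)[nH]n2)cc(OC)c1OC`, 4020 nM
compound 3 `COc1ccc(C(=O)/C=C/c2cc(-c3cc(OC)c(OC)c(OC)c3)n[nH]2)cc1`, 3740 nM

Compound 2 stands second highest of the three numbers in this assay; its nearest neighbour is compound 1 and its furthest is compound 3, both within the scatter, so the three are not ordered.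

Compound 4 `COc1ccc(-c2cc(/C=C/C(=O)c3ccc(N)cc3)[nH]n2)cc1OC` differs from compound 2 in one place: hydrogen in place of methoxy on an aromatic carbon. Among the compounds with values here, no measured step removes a methoxy from this ring. Within the data shown here, the one measured step, a 1.1-fold lower number from compound 2 to compound 3 (0.03 log units; within the scatter), concerns a different part of the molecule and lies within the scatter. Compared with compound 2, compound 1 carries fewer methoxy groups on that ring; in this assay compound 1 gives 4210 nM, within the scatter of compound 2.

On this basis no step beyond the scatter is expected, and compound 4 is estimated at 4100 nM (range 2000 nM to 8500 nM), a step of a 1.0-fold higher number from compound 2 to compound 4 (0.01 log units; within the scatter).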

Compound 4, concentration for total growth inhibition: 19500 nM
For compound 4 the middle estimate is 4.8-fold (0.68 log units) below the measured one; the whole stated range lies below it.
By their numbers in this assay, from the lowest: compounds 3, 2 and 1 (each within the scatter of the next); then compound 4.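

In this assay the methoxy pattern on this ring matters after all: removing one methoxy gives a 4.9-fold higher number from compound 2 to compound 4 (0.69 log units; beyond the scatter) and adding one gives a 4.6-fold higher number from compound 1 to compound 4 (0.67 log units; beyond the scatter) so both single changes arrive at weaker growth inhibition in compound 4. The number therefore does not follow the methoxy count in a single direction across these steps. No measurement given here explains this result.

Open, going by these compounds, is whether a hydroxy group or a chlorine on this aromatic carbon would give a number close to compound 2 or close to compound 4. Also open, on these data alone, is whether methoxy in place of amino stays within the scatter on compound 4.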